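Removing the chloro group from compound 2

A few compounds are considered here, and "the series" means these few. Any claim that something is new, unique, unknown or untested is made for them only; others in the source may bear on it.

Measured compounds:
compound 1, `COc1ccccc1-n1c(Nc2nc(-c3ccccc3)cs2)n[nH]c1=S`, 300 mg/kg
compound 2, `Cc1ccc(-n2c(Nc3nc(-c4ccc(Cl)cc4)cs3)n[nH]c2=S)cc1`, 300 mg/kg

The two measured compounds were tested in a functional assay on the whole organism (strain Swiss albino) for inhibition, with Mus musculus as the target, with a stated time of 4 h; a higher number here means that more compound is needed for the effect, a lower number that less compound is needed. In this assay compound 1 gives 300 mg/kg, and compound 2 gives 300 mg/kg in the same assay. Compound 2 therefore stands level with compound 1 at the digits reported; the two values lie within the usual scatter, so nothing separates them.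

The next compound, compound 3, `Cc1ccc(-n2c(Nc3nc(-c4ccccc4)cs3)n[nH]c2=S)cc1`, has not yet been measured in this assay. Compound 3 differs from compound 2 in one place, (hydrogen in place of chloro on an aromatic carbon). Going by the values given here, no step between two measured compounds is available for this change. Among the compounds with values here, the only guide is that compound 1, which also carries an unsubstituted phenyl ring and gives 300 mg/kg, sits where compound 2 sits, so a step of no size beyond the scatter is expected in this assay. Compound 3 is estimated at 300 mg/kg, with a range from 150 mg/kg to 600 mg/kg, which means an expected step of no change at the digits printed from compound 2 to compound 3 (within the scatter).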

Compound 3, minimum effective dose: 300 mg/kg
Beside the measured number, compound 3's estimate shows no gap at the digits printed, within the range that was stated.
By their numbers in this assay, from the lowest: compounds 1, 2 and 3 (each within the scatter of the next).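

In this assay, the exchange of 4-chlorophenyl for phenyl now has a direct reading: with hydrogen in place of chloro on an aromatic carbon, para to a large group, the result is no change at the digits printed from compound 2 to compound 3 (within the scatter). Compound 3 also links the two groups on the aromatic nitrogen, since 4-methylphenyl in place of 2-methoxyphenyl gives no change at the digits printed from compound 1 to compound 3 (within the scatter), so neither change separates these compounds in this assay. No other measurement is available to explain this result.

With all three compounds reading the same value, the data leave open whether this assay can distinguish compounds at either position, or whether these few changes are simply too limited to reveal a difference. An amine or a carboxylic acid on that aromatic carbon, or a longer chain on the aromatic nitrogen in place of the substituted phenyl groups, would test these positions more widely, and the outcome of such changes cannot be inferred from the present values.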